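The source may hold more compounds than are shown below. What is called first, only, known or untested is meant among the compounds shown, and "the series" means these compounds.

Measured so far in an assay for binding affinity to dual specificity mitogen-activated protein kinase kinase 4 (Homo sapiens), read by KINOMEscan, tested at 100 nM; a higher number here means a weaker effect of the compound at the concentration tested, a lower number a stronger effect:
- compound 1 `CCCS(=O)(=O)Nc1ccc(F)c(C(=O)c2n[nH]c3ncc(-c4ccc(F)cc4)cc23)c1F`, which gives 2.1%
- compound 2 `CCCS(=O)(=O)Nc1ccc(F)c(C(=O)c2n[nH]c3ncc(-c4cccc(O)c4)cc23)c1F`, which gives 2.2%
- compound 3 `CCCS(=O)(=O)Nc1ccc(F)c(C(=O)c2n[nH]c3ncc(-c4ccc(N)cc4)cc23)c1F`, which gives 0.1%

All three numbers sit close to one another. Compound 3 differs from compound 1 by a number 2 percentage points lower from compound 1 to compound 3 (within the scatter) and from compound 2 by a number 2.1 percentage points lower from compound 2 to compound 3 (within the scatter); the change from compound 1 to compound 2 is a number 0.1 percentage points higher from compound 1 to compound 2 (within the scatter). None of these steps leaves the scatter, so compound 3 is not set apart from the other two on this read-out.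

Compound 4 `CCCS(=O)(=O)Nc1ccc(F)c(C(=O)c2n[nH]c3ncc(-c4ccc(-c5nnn[nH]5)cc4)cc23)c1F` has not yet been measured. It differs from compound 3 as follows: 1H-tetrazol-5-yl in place of amino on an aromatic carbon. For the measured compounds named here, the steps that bear on this position are those into compound 3, where amino replaced fluoro on the aromatic carbon and 4-aminophenyl replaced 3-hydroxyphenyl; both moved the number only within the scatter. Going by the values given here, no measured step covers the 1H-tetrazol-5-yl group itself, so the expectation rests on the indifference of this position so far.

The expected step from compound 3 to compound 4 is therefore a number 2.9 percentage points higher from compound 3 to compound 4 (within the scatter), that is none beyond the scatter in either direction. For compound 4 the value in this assay is estimated at 3%, with a range from 0.1% to 15%.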

Compound 4, a percentage reported as activity, at one concentration (the size of the read-out at that concentration, not a potency): 0.15%
For compound 4 the middle estimate is 2.9 percentage points above the measured one, and the stated range covers the measured number.
By their numbers in this assay, from the lowest: compounds 3, 4, 1 and 2 (each within the scatter of the next).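

In this assay, the change from 4-aminophenyl to 4-(1H-tetrazol-5-yl)phenyl gives a number 0.1 percentage points higher from compound 3 to compound 4 (within the scatter), so a five-membered aromatic ring with 4 hetero atoms, 5 heavy atoms in place of 1, can stand on this aromatic carbon, para to a large group, without a step beyond the scatter. The two other steps into the tetrazole read the same way, with a number 2 percentage points lower from compound 1 to compound 4 (within the scatter) and a number 2.1 percentage points lower from compound 2 to compound 4 (within the scatter), which extends the indifference seen with fluoro, amino and the 3-hydroxyphenyl variant to a much larger substituent that carries a ring of its own. Nothing measured in this set gives a reason for that indifference.

From the compounds shown here alone, all four compounds sit close together at the single concentration of this assay, so any stronger or weaker effect among them that this read-out does not resolve remains open, and measurements at further concentrations would be needed to show one. For the compounds shown here, it also remains open whether a carboxylic acid, a morpholine or a longer alkyl chain at the same place on the phenyl ring would produce the first step beyond the scatter.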